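From 3-nitrophenyl to 4-nitrophenyl in a weakly active pair

This account rests on a few compounds, and the source may have more. Where it says the series, first, only, none or still open, it means among the compounds named here.

compound 1 `CC1(C)Cc2c(ccc(C(=O)/C=C/c3cn(-c4ccccc4)nc3-c3cccc([N+](=O)[O-])c3)c2OCc2ccccc2)O1`: > 100000 nM
compound 2 `COc1ccc(-c2nn(-c3ccccc3)cc2/C=C/C(=O)c2ccc(O)c3c2OC(C)(C)C3)cc1`: 20800 nM

Of the compounds shown here, two have so far been measured in a functional assay on PC-3 cells (Homo sapiens) for antiproliferative activity, read by MTT assay, with a stated time of 48 h; on this read-out higher numbers stand for weaker inhibition and lower numbers for stronger inhibition. Compound 1 `CC1(C)Cc2c(ccc(C(=O)/C=C/c3cn(-c4ccccc4)nc3-c3cccc([N+](=O)[O-])c3)c2OCc2ccccc2)O1` returns only a limit of the assay, > 100000 nM, so no number is known for it. Compound 2 `COc1ccc(-c2nn(-c3ccccc3)cc2/C=C/C(=O)c2ccc(O)c3c2OC(C)(C)C3)cc1` gives 20800 nM in this assay, a weak result in its own right. For the measured compounds named here, no pair of measured compounds differs in only one place, so no measured step is available to guide the next comparison.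

Compound 3 `CC1(C)Cc2c(ccc(C(=O)/C=C/c3cn(-c4ccccc4)nc3-c3ccc([N+](=O)[O-])cc3)c2OCc2ccccc2)O1` differs from compound 1 by 4-nitrophenyl in place of 3-nitrophenyl on an aromatic carbon. Compound 1 stands at the limit of > 100000 nM in this assay, at which 1 of the 2 values shown sits. With nothing but that limit to go on, the shift a number no higher from compound 1 to compound 3 (the limit leaves the size open) is expected to stay within the usual scatter, and a second limit is a real possibility. Compound 3 is therefore estimated at about 100000 nM, with a range from 30000 nM to 300000 nM.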

Compound 3, half-maximal inhibitory concentration: 62300 nM
For compound 3 the middle estimate is 1.6-fold (0.21 log units) above the measured one, within the range that was stated.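

The change to 4-nitrophenyl gives a measured number at a place on the five-membered ring where 3-nitrophenyl gave only a limit, an at least 1.6-fold lower number from compound 1 to compound 3 (0.20 log units; that floor lies within the scatter). Only the floor of this step is known, and since it lies within the scatter, the change cannot be called a real gain in this assay. The true size of the step stays open, and the reading rests on a single limit: the limit of > 100000 nM in this assay, at which 1 of the 3 values shown sits.

The compounds shown leave open whether an amine or a carboxylic acid in place of the nitro group on this phenyl ring would move the number at all. They also leave open how much the benzyl ether of the shared core contributes, as compound 2 differs from compound 3 in more than one place.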